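This account rests on a few compounds, and the source may have more. Where it says the series, first, only, none or still open, it means among the compounds named here.

For the measured compounds named here, in a physicochemical assay for solubility, in phosphate buffer, at pH 7.4 (a lower number here means a less soluble compound, a higher number a more soluble compound), compound 3 (`CC(=O)N[C@@H]1CCC[C@H](C(=O)Nc2cc(-c3cnc4ccccn34)c(Cl)cn2)C1`) gives 120000 nM, the lowest of the three numbers measured so far. Compound 2 (`CC(=O)N[C@@H]1CCC[C@H](C(=O)Nc2cc(-c3cnc4n3CCCC4)c(Cl)cn2)C1`) gives 600000 nM and compound 1 (`CC(=O)N[C@@H]1CCC[C@H](C(=O)Nc2cc(-c3cnn4c3CCCC4)ccn2)C1`) gives 730000 nM. Compound 4 (`CC(=O)N[C@@H]1CCC[C@H](C(=O)Nc2cc(-c3cnn4c3COCC4)c(Cl)cn2)C1`) has not yet been measured. It differs from compound 3 as follows: a group of 9 heavy atoms (6 carbon, 2 nitrogen, 1 oxygen; one five-membered aromatic ring with 2 hetero atoms, one six-membered non-aromatic ring with 2 hetero atoms) in place of a group of 9 heavy atoms (7 carbon, 2 nitrogen; one five-membered aromatic ring with 2 hetero atoms, one six-membered aromatic ring with 1 hetero atom), on an aromatic carbon. In compound 4, a group with one six-membered non-aromatic ring with 2 hetero atoms stands in place of a group with one six-membered aromatic ring with 1 hetero atom, ortho to a chloro group.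

Going by the values given here, one measured step bears on this: a 5.0-fold lower number from compound 2 to compound 3 (0.70 log units; beyond the scatter). That modest step also exchanged a six-membered non-aromatic ring for a six-membered aromatic ring, so the change to compound 4 runs broadly the opposite way, although the two non-aromatic groups are not the same. A step of similar size, towards a higher number, is therefore expected in this assay. The expected step is a 3.8-fold higher number from compound 3 to compound 4 (0.57 log units; beyond the scatter). Compound 4 is estimated at 450000 nM, with an expected range of 180000 nM to 1000000 nM.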

Compound 4, solubility: 220000 nM
Estimate against measurement, compound 4: 2.0-fold (0.31 log units) above; the measured number falls inside the stated range.
By their numbers in this assay, from the lowest: compounds 3 and 4 (each within the scatter of the next); then compounds 2 and 1 (each within the scatter of the next).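

In this assay, the exchange ortho to a chloro group, opposite the ring nitrogen, gives a 1.8-fold higher number from compound 3 to compound 4 (0.26 log units; within the scatter), so the group with the six-membered non-aromatic ring with 2 hetero atoms cannot be told apart from the group with the six-membered aromatic ring with 1 hetero atom. Compound 2 also carries a six-membered non-aromatic ring at this place, yet a 2.7-fold lower number from compound 2 to compound 4 (0.44 log units; beyond the scatter) is beyond the scatter, so among these compounds a non-aromatic ring alone does not set the number, and the two non-aromatic groups differ. Nothing available accounts for either step.

The compounds shown leave open how the number would respond to an amine or a carboxylic acid on the non-aromatic ring of compound 4. No pair shown isolates the chloro group either, as compound 1 also differs in its ring group.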